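A few compounds are considered here, and "the series" means these few. Any claim that something is new, unique, unknown or untested is made for them only; others in the source may bear on it.

Measured so far:
- compound 1, `COc1ccc(OC)c(-c2cc(-c3ccc(C(=O)N4CCCC4)s3)on2)c1`: in a functional assay on A549 cells (Homo sapiens) for cytotoxicity, read by XTT assay, with a stated time of 72 h (a lower number here means a stronger inhibitor, a higher number a weaker inhibitor), compound 1 gives only a limit, > 30000 nM
- compound 2, `O=C1C=CC(=O)C(c2cc(-c3ccc(C(=O)N4CCCC4)s3)on2)=C1`: in this assay compound 2 likewise gives only a limit, > 30000 nM

Going by the values given here, compound 1 therefore stands nowhere on a scale of numbers: its value is a limit of the assay, not a measurement, and the one other value shown is also a limit. the limit of > 30000 nM in this assay, at which 2 of the 2 values shown sit, sums up what is known, and no step between measured compounds exists from which a size of effect could be read.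

Compound 3, `COc1ccc(CN(C)C(=O)c2ccc(-c3cc(-c4cc(OC)ccc4OC)no3)s2)cc1`, differs from compound 1 by (4-methoxybenzyl)(methyl)amino in place of pyrrolidin-1-yl on a carbonyl carbon. Both measured compounds sitting at the limit, nothing in the data points to a direction or a size for this change. The step from compound 1 to compound 3 is expected to be none beyond the scatter, a step that the limit leaves unreadable from compound 1 to compound 3, with the result most likely again reported as a limit. Compound 3 is estimated at 40000 nM in this assay, within a range of 10000 nM to 150000 nM.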

Compound 3, half-maximal inhibitory concentration: > 30000 nM
Compound 3 was reported as a limit; the forecaster's own chance of this, stated with the estimate: 75%; the middle value lies beyond the limit too.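

In this assay compound 3 gives > 30000 nM, a limit of the assay. Compound 1 also gives only a limit, so no step from compound 1 to compound 3 can be read: the limit of > 30000 nM in this assay, at which 3 of the 3 values shown sit.

The compounds shown leave open which change, if any, to the shared core or the group on the carbonyl carbon would give a measurable value.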